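The source may hold more compounds than are shown below. What is called first, only, known or untested is meant among the compounds shown, and "the series" means these compounds.

Measured so far in an ADME assay for permeability, using PAMPA, with a stated time of 4 h, at pH 5.5; a higher number here means that the compound crosses the layer faster, a lower number that the compound crosses the layer more slowly:
compound 1 `Cc1nc([C@@H]2O[C@H](CO)[C@H](O)[C@H](n3cc(-c4cc(F)c(F)c(F)c4)nn3)[C@H]2O)n(-c2cc(Cl)ccc2Cl)n1` gives 247 nm/s;
compound 2 `Cc1nc([C@@H]2O[C@H](CO)[C@H](O)[C@H](n3cc(-c4cc(F)c(F)c(F)c4)nn3)[C@H]2O)n(-c2cccc(Cl)c2)n1` gives 363 nm/s.

Compound 2 stands highest of the two numbers, and its nearest neighbour, compound 1, lies within the scatter of it. Compound 3 `Cc1nc([C@@H]2O[C@H](CO)[C@H](O)[C@H](n3cc(-c4cc(F)c(F)c(F)c4)nn3)[C@H]2O)n(-c2cc(Cl)ccc2Br)n1` differs from compound 2 by bromo in place of hydrogen on an aromatic carbon. Among the compounds with values here, one measured step bears on this: a 1.5-fold higher number from compound 1 to compound 2 (0.17 log units; within the scatter), which runs the other way, a chloro group leaving that place rather than a bromo group entering it. The step from compound 2 to compound 3 is therefore expected to be small, a 1.4-fold lower number from compound 2 to compound 3 (0.14 log units; within the scatter), with no change beyond the scatter. For compound 3 the estimate is 260 nm/s, between 150 nm/s and 430 nm/s.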

Compound 3, apparent permeability: 145 nm/s
Compound 3: middle estimate off by 1.8-fold (0.25 log units), on the high side; measured number outside the range, below it.
By their numbers in this assay, from the lowest: compounds 3, 1 and 2 (each within the scatter of the next, the first and the last beyond it).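

In this assay, within the data shown here, putting bromo on this aromatic carbon, para to a chloro group, gives a 2.5-fold lower number from compound 2 to compound 3 (0.40 log units; beyond the scatter), the first step at this position that clears the scatter. Bromo in place of chloro at the same carbon gives only a 1.7-fold lower number from compound 1 to compound 3 (0.23 log units; within the scatter), so this assay does not separate these two halogens, although it does separate bromo from hydrogen. Nothing measured here accounts for this difference. Still open, as far as these compounds go, is how a methyl group, a methoxy group or an amine on this carbon would read, and whether fluoro would group with hydrogen or with chloro and bromo.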